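The source may report more compounds than this note shows. Statements on the series, on what has been measured and on what is new or still open speak of the compounds shown alone.

Compound 1 `O=C1CC(c2cnco2)CN1c1cnn2c1CN(C(=O)Nc1cc(F)c(F)c(F)c1)C(C1CC1)C2` is the reference point of this set. Within the data shown here, in a toxicity assay on HepG2 2.2.15 cells (Homo sapiens) for cytotoxicity, read by CellTiter-Glo (on this read-out higher numbers stand for lower toxicity in this test and lower numbers for higher toxicity in this test), compound 1 gives 139000 nM, which is the highest number of the three measured so far. Compound 2 `O=C1NC(c2ccccc2)CN1c1cnn2c1CN(C(=O)Nc1cc(F)c(F)c(F)c1)C(C1CC1)C2` gives 38500 nM, and compound 3 `O=C1CC(c2ccccc2)CN1c1cnn2c1CN(C(=O)Nc1cc(F)c(F)c(F)c1)C(C1CC1)C2` gives 12800 nM. The steps among them all run downward from compound 1: a 3.6-fold lower number from compound 1 to compound 2 (0.56 log units; beyond the scatter), an 11-fold lower number from compound 1 to compound 3 (1.04 log units; beyond the scatter) and a 3.0-fold lower number from compound 2 to compound 3 (0.48 log units; beyond the scatter).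

Compound 4 `Cc1cnc(C2CC(=O)N(c3cnn4c3CN(C(=O)Nc3cc(F)c(F)c(F)c3)C(C3CC3)C4)C2)s1` has not yet been measured. It differs from compound 1 by 5-methyl-1,3-thiazol-2-yl in place of 1,3-oxazol-5-yl on a saturated ring carbon. The step that bears most directly on it is the swap on the same saturated ring carbon in which phenyl replaced 1,3-oxazol-5-yl, an 11-fold lower number from compound 1 to compound 3 (1.04 log units; beyond the scatter), a large lowering. The entering 5-methyl-1,3-thiazol-2-yl is still a five-membered aromatic ring with two hetero atoms and two hydrogen-bond acceptors, so the change is less far-reaching than the move to phenyl; a lowering is expected, but a modest one, with the phenyl case of compound 3 as the likely floor. The expected step is a 2.3-fold lower number from compound 1 to compound 4 (0.36 log units; beyond the scatter). Compound 4 is therefore estimated at 60000 nM, within a range from 20000 nM to 160000 nM.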

Compound 4, half-maximal cytotoxic concentration: 96200 nM
Estimate against measurement, compound 4: 1.6-fold (0.21 log units) below; measured number inside the range.
By their numbers in this assay, from the lowest: compound 3; then compound 2; then compounds 4 and 1 (each within the scatter of the next).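

In this assay, among these compounds, the swap on this saturated ring carbon gives a 1.4-fold lower number from compound 1 to compound 4 (0.16 log units; within the scatter), so a second five-membered aromatic ring with 2 hetero atoms can stand here with no step beyond the scatter, whereas the earlier compounds offered only phenyl as an alternative to 1,3-oxazol-5-yl at this position. The large step seen with phenyl therefore does not follow from every loss of 1,3-oxazol-5-yl, and the direct comparison at this carbon gives a 7.5-fold higher number from compound 3 to compound 4 (0.88 log units; beyond the scatter). The step of a 2.5-fold higher number from compound 2 to compound 4 (0.40 log units; beyond the scatter) extends the same picture to the changed lactam-bearing group: among these four compounds, the two carrying phenyl, compound 2 and compound 3, both have lower numbers than the two carrying a five-membered aromatic ring, and none goes against this.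

Whether the methyl group of 5-methyl-1,3-thiazol-2-yl contributes anything remains open, since an unsubstituted 1,3-thiazol-2-yl is not among the compounds shown, and the same holds for how a non-aromatic group at this carbon, such as an amine or a carboxylic acid, would read. Nothing available here accounts for the gap between the phenyl compounds and the five-membered aromatic ones.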